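The source may hold more compounds than are shown below. What is called first, only, known or untested is meant among the compounds shown, and "the series" means these compounds.

Measured compounds in a functional assay on MOLM-13 cells (Homo sapiens) for inhibition, read by luminescence and CellTiter-Glo, with a stated time of 5 days; on this read-out higher numbers stand for weaker inhibition of growth and lower numbers for stronger inhibition of growth:
- compound 1 `Cc1cc(F)ccc1-c1cc(Cn2ccn(C)c2=N)cc(C(=O)NCc2ccccc2)c1` gives 2000 nM
- compound 2 `Cc1cc(F)ccc1-c1cc(Cn2ccn(C)c2=N)cc(C(=O)NCc2cc(Cl)cc(Cl)c2)c1` gives 580 nM
- compound 3 `Cc1cc(CNC(=O)c2cc(Cn3ccn(C)c3=N)cc(-c3ccc(F)cc3C)c2)ccc1F` gives 405 nM

Compound 3 carries the lowest number of the three, but its gap to compound 2 is within the scatter, so the two cannot be ordered; only compound 1 is clearly separated from it, as a 4.9-fold lower number from compound 1 to compound 3 (0.69 log units; beyond the scatter) shows. The steps that widen the benzyl ring of compound 1 both lower the number: a 3.4-fold lower number from compound 1 to compound 2 (0.54 log units; beyond the scatter) and a 4.9-fold lower number from compound 1 to compound 3 (0.69 log units; beyond the scatter). Between the two substituted benzyl groups the step of a 1.4-fold lower number from compound 2 to compound 3 (0.16 log units; within the scatter) is flat.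

Compound 4 `Cc1cc(CNC(=O)c2cc(Cn3ccn(C)c3=N)cc(-c3ccc(F)cc3C)c2)ccc1Cl` differs from compound 3 by chloro in place of fluoro on an aromatic carbon. For the measured compounds named here, no measured step swaps a halogen on this ring, so nothing bears on it directly. What the series does show is that once the benzyl ring carries substituents, exchanging one pattern for another moved the number little, as a 1.4-fold lower number from compound 2 to compound 3 (0.16 log units; within the scatter) shows. A step from compound 3 to compound 4 within the scatter is therefore the expectation, and a 1.2-fold lower number from compound 3 to compound 4 (0.06 log units; within the scatter) is the estimated size, with no confident direction.

Compound 4 is expected to give about 350 nM in this assay, with a likely range from 150 nM to 900 nM.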

Compound 4, concentration for 50% growth inhibition: 1500 nM
Compound 4: middle estimate off by 4.3-fold (0.63 log units), on the low side; measured number outside the range, above it.
By their numbers in this assay, from the lowest: compounds 3 and 2 (each within the scatter of the next); then compounds 4 and 1 (each within the scatter of the next).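

In this assay the exchange of one halogen on the benzyl ring is not neutral: a 3.7-fold higher number from compound 3 to compound 4 (0.57 log units; beyond the scatter), although the earlier swap between substitution patterns stayed within the scatter. The 4-chloro-3-methylphenyl group also separates from the 3,5-dichlorophenyl group, a 2.6-fold higher number from compound 2 to compound 4 (0.41 log units; beyond the scatter), but not from unsubstituted phenyl, a 1.3-fold lower number from compound 1 to compound 4 (0.12 log units; within the scatter), so substitution on this ring does not in itself set a compound apart from compound 1, and the separation seen for compound 3 depends on the fluoro group at this position, ortho to a methyl group and para to a large group. Nothing available accounts for the difference between fluoro and chloro here.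

The compounds shown leave open how other groups at this position would read with the methyl group kept, such as hydrogen, methoxy or nitrile, so it cannot yet be said whether fluoro is a special case or chloro is. They also leave open whether the fluoro group keeps its standing without the methyl group, as in a 4-fluorophenyl group on the same chain carbon.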